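The source may report more compounds than this note shows. Statements on the series, on what has been measured and on what is new or still open speak of the compounds shown alone.

Compound 1 `Cc1[nH]c2ccccc2c1C1CC(c2ccncc2)=NO1` is one of three compounds tested in a functional assay on CWR22R cells (Homo sapiens) for inhibition, read by MTT assay, with a stated time of 48 h (a higher number here means a weaker inhibitor, a lower number a stronger inhibitor), where compound 1 gives 17300 nM. Compound 2 `COc1ccc(C2=NOC(c3c[nH]c4ccccc34)C2)cc1OC` gives 16700 nM in this assay, a value within the usual scatter of that of compound 1, so the two cannot be told apart. Compound 3 `COc1ccc2[nH]cc(C3CC(c4ccncc4)=NO3)c2c1` gives 35500 nM, a higher number than compound 1 by more than the scatter, so compound 3 is the weaker inhibitor of that pair. Compound 4 `Cc1c(C2CC(c3ccncc3)=NO2)c2ccccc2n1Cc1ccc(Cl)cc1` has not yet been measured; it differs from compound 1 by 4-chlorobenzyl in place of hydrogen on an aromatic nitrogen. Within the data shown here, no measured pair shows this kind of change, so its effect is uncertain. Compound 4 is expected to give 9000 nM, with a likely range from 2500 nM to 30000 nM. The estimated step of a 1.9-fold lower number from compound 1 to compound 4 (0.28 log units; within the scatter) would point toward stronger inhibition, though a step of no size beyond the scatter remains plausible.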

Compound 4, half-maximal inhibitory concentration: 8330 nM
For compound 4 the middle estimate is 1.1-fold (0.03 log units) above the measured one, and the stated range covers the measured number.
By their numbers in this assay, from the lowest: compounds 4, 2 and 1 (each within the scatter of the next, the first and the last beyond it); then compound 3.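

Replacing hydrogen with 4-chlorobenzyl on the aromatic nitrogen gives a 2.1-fold lower number from compound 1 to compound 4 (0.32 log units; beyond the scatter) in this assay. This is the only single-place comparison among these compounds, and it shows that this nitrogen need not keep its hydrogen: a much larger group is accepted, and inhibition becomes modestly stronger. Nothing available here explains the step.

The compounds shown leave open whether the chlorine matters, and whether a plain benzyl, a methyl or a longer chain ending in an amine on this nitrogen would give a similar number.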